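Methyl for chloro on the aryl ring of the oxime series

The compounds below may be only part of what the source reports. "The series", "measured", "known", "first", "only" and "open" are said of these compounds alone.

Measured so far in a functional assay on HEK293 cells with D(4) dopamine receptor (Homo sapiens) as the target, read by FLIPR; a higher number here means a larger maximal response, a lower number a smaller maximal response:
compound 1 `O/N=C(\CCN1CCN(c2ccccn2)CC1)c1cccc(Cl)c1`: 73%
compound 2 `Cc1cccc(/C(CCN2CCN(c3ccccn3)CC2)=N/O)c1`: 74%
compound 3 `CO/N=C(\CCN1CCN(c2ccccn2)CC1)c1ccccc1Cl`: 79%

Compound 1 and compound 2 share one core; compound 3 and the unmeasured compound 4 `CO/N=C(\CCN1CCN(c2ccccn2)CC1)c1ccccc1C` share another. The difference between the two cores is not broken down here. All three measured values in this assay lie within the usual scatter of one another, so no order among them can be read.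

The change from compound 1 to compound 2 is methyl in place of chloro on an aromatic carbon, and it gave a number 1 percentage points higher from compound 1 to compound 2 (within the scatter). The change from compound 3 to compound 4 is methyl in place of chloro on an aromatic carbon. The place of the group differs: meta to a large group in the first pair, ortho to a large group in the second, so this is the same kind of change rather than the same one. Among the compounds with values here, only one measured example of it exists in this set.

The maximal response of compound 4 in this assay is expected to stay close to that of compound 3, because a number 1 percentage points higher from compound 1 to compound 2 (within the scatter) shows the same kind of change leaving the response essentially unmoved. The step for compound 4 is estimated as a number 1 percentage points higher from compound 3 to compound 4 (within the scatter). With the place of the group now being ortho rather than meta, the range allowed around this expectation is kept somewhat wider than the scatter alone would demand. Compound 4 is estimated at 80%, between 66% and 92%.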

Compound 4, largest response reached (reported as efficacy), in percent of the reference or control that the assay uses: 80%
The estimate for compound 4 equals the measured number at the digits printed, and the stated range covers the measured number.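

In this assay, methyl in place of chloro on an aromatic carbon, here ortho to a large group, gives a number 1 percentage points higher from compound 3 to compound 4 (within the scatter). Set beside the earlier step on the other core, the change carries from one core to the other with no readable difference: the same change on two cores in this assay, a number 1 percentage points higher (within the scatter) from compound 1 to compound 2 and a number 1 percentage points higher (within the scatter) from compound 3 to compound 4, 0 percentage points apart, within the scatter of two such steps. Within the data shown here, this shows that the swap leaves the maximal response within the scatter on both cores, but it rests on only two pairs in which the place of the group is not the same, and it says nothing about other read-outs, other cores or other places on the ring, so no general rule follows.

Chloro and methyl are the only groups varied on this ring among the compounds shown, and both sit within the scatter, so it remains open whether any group on the ring moves the maximal response at all; methoxy, trifluoromethyl or an amine at the same place would test this. Also open, on these data alone, is how the response would answer to a longer chain between the oxime carbon and the basic end of the molecule.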